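The compounds below may be only part of what the source reports. "The series", "measured", "known", "first", "only" and "open" are said of these compounds alone.

Compound 1 `N#C/N=C(\NCc1ccc(S(=O)(=O)c2ccccc2)cc1)Nc1ccncc1` — in a functional assay on A2780 cells (Homo sapiens) for antiproliferative activity, read by sulforhodamine B assay, with a stated time of 72 h (a lower number here means a stronger inhibitor, a higher number a weaker inhibitor), compound 1 gives 9.7 nM.
Compound 2 `N#C/N=C(\NCc1ccc(S(=O)(=O)c2cccc3cccnc23)cc1)Nc1ccncc1` — in this assay compound 2 gives 14 nM.

Compound 2 cannot be told apart from compound 1 on these numbers: the step of a 1.4-fold higher number from compound 1 to compound 2 (0.16 log units; within the scatter) lies within the scatter, so the two sit level. Compound 3 `N#C/N=C(\NCc1ccc(S(=O)(=O)C2CCCCC2)cc1)Nc1ccncc1` differs from compound 2 by cyclohexyl in place of quinolin-8-yl on a sulfonyl sulfur. Among the measured compounds shown here, the only measured step that bears on this is the exchange at the same sulfonyl sulfur, a 1.4-fold higher number from compound 1 to compound 2 (0.16 log units; within the scatter), which was within the scatter. For the measured compounds named here, that step swapped one aromatic ring for another; no measured compound carries a non-aromatic ring at this position, so the effect of a cyclohexyl here is untested. The expectation is therefore a step of a 1.4-fold higher number from compound 2 to compound 3 (0.15 log units; within the scatter) that stays close to the scatter, with a wide band of uncertainty. Compound 3 is thus estimated at 20 nM in this assay, within a range of 6 nM to 70 nM.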

Compound 3, half-maximal inhibitory concentration: 14.8 nM
Compound 3: middle estimate off by 1.4-fold (0.13 log units), on the high side; the range from low to high includes it.
By their numbers in this assay, from the lowest: compounds 1, 2 and 3 (each within the scatter of the next).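

The sulfonyl sulfur now carries a non-aromatic ring among the compounds shown, and in this assay cyclohexyl in place of quinolin-8-yl gives a 1.1-fold higher number from compound 2 to compound 3 (0.02 log units; within the scatter), while cyclohexyl in place of phenyl gives a 1.5-fold higher number from compound 1 to compound 3 (0.18 log units; within the scatter). Across these three compounds, an aromatic ring on the sulfonyl sulfur is therefore not needed to keep the number level, and neither is the hydrogen-bond acceptor counted in quinolin-8-yl, which cyclohexyl lacks. Nothing given here accounts for this flat result.

All three groups are carbon-based rings, so the compounds shown leave open whether the level holds for a group of another kind on the sulfonyl sulfur. An amine, a carboxylic acid or an open alkyl chain there could give a different number.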